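Fluoro in place of methoxy in compound 3

The source may report more compounds than this note shows. Statements on the series, on what has been measured and on what is new or still open speak of the compounds shown alone.

In a functional assay on MCF7 cells (Homo sapiens) for antiproliferative activity, with a stated time of 5 days (on this read-out lower numbers stand for stronger inhibition and higher numbers for weaker inhibition), compound 1 (`COc1ccc(-c2[nH]c3cc(F)ccc3c2C=O)cc1`) gives 43 nM and compound 2 (`COc1ccc(-c2[nH]c3cc(OC)ccc3c2C=C(C#N)C#N)cc1`) gives 300 nM as the higher of the two numbers, a gap beyond the scatter. Relative to compound 2, compound 3 (`COc1ccc(-c2[nH]c3cc(F)ccc3c2C=C(C#N)C#N)cc1`) carries fluoro in place of methoxy on an aromatic carbon. Among the measured compounds shown here, no single-change step between measured compounds is available, so in this assay no shift beyond the scatter is expected, with a slight lean toward a lower number. The expected change is a 1.7-fold lower number from compound 2 to compound 3 (0.22 log units; within the scatter) in this estimate. For compound 3 the estimated value is 180 nM (expected range 60 nM to 550 nM).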

Compound 3, half-maximal inhibitory concentration: 220 nM
The estimate for compound 3 lay 1.2-fold (0.09 log units) below the measured number, and the stated range covers the measured number.
By their numbers in this assay, from the lowest: compound 1; then compounds 3 and 2 (each within the scatter of the next).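

In this assay, fluoro in place of methoxy on this aromatic carbon gives a 1.4-fold lower number from compound 2 to compound 3 (0.13 log units; within the scatter) with the 2,2-dicyanoethenyl group held constant, so the two substituents cannot be told apart here. With fluoro held constant, 2,2-dicyanoethenyl in place of formyl gives a 5.1-fold higher number from compound 1 to compound 3 (0.71 log units; beyond the scatter) as the first single-change read on that group, and this step lies beyond the scatter. No available evidence accounts for either step. Open, on these data alone, is how an amine or a carboxylic acid on this carbon would read, and whether formyl keeps its advantage with methoxy there.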